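Notes on compound 4: chloro for fluoro step

This account rests on a few compounds, and the source may have more. Where it says the series, first, only, none or still open, it means among the compounds named here.

Measured compounds in an assay on isolated protein for inhibition of Amine oxidase [flavin-containing] A (Homo sapiens), read by fluorescence, with stated times of 15 min and 20 min; on this read-out lower numbers stand for stronger inhibition and higher numbers for weaker inhibition:
compound 1 `CC(C)(C)c1cc(/C=C/C(=O)NC2CCN(Cc3ccccc3)CC2)cc(C(C)(C)C)c1O` gives 42500 nM
compound 2 `Cc1ccccc1CN1CCC(CCNC(=O)/C=C/c2cc(C(C)(C)C)c(O)c(C(C)(C)C)c2)CC1` gives 69300 nM
compound 3 `CC(C)(C)c1cc(/C=C/C(=O)NCCC2CCN(Cc3cccc(F)c3)CC2)cc(C(C)(C)C)c1O` gives 58400 nM

Compound 3 stands second highest of the three numbers in this assay, with compound 2 nearest and compound 1 furthest, both gaps within the scatter. Within the data shown here, the one measured step, a 1.2-fold lower number from compound 2 to compound 3 (0.07 log units; within the scatter), also lies within the scatter.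

Compound 4 `CC(C)(C)c1cc(/C=C/C(=O)NCCC2CCN(Cc3cccc(Cl)c3)CC2)cc(C(C)(C)C)c1O` differs from compound 3 by chloro in place of fluoro on an aromatic carbon. Among the measured compounds shown here, no measured step exchanges one halogen for another on this ring, so nothing here bears directly on the change; the only step in the set, a 1.2-fold lower number from compound 2 to compound 3 (0.07 log units; within the scatter), shows that varying the substituent on this benzyl ring left the number within the scatter. A step no larger than the scatter, in either direction, is therefore expected in this assay for compound 4, that is a 1.2-fold lower number from compound 3 to compound 4 (0.07 log units; within the scatter).

Compound 4 is estimated at 50000 nM in this assay, with a range from 20000 nM to 150000 nM.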

Compound 4, half-maximal inhibitory concentration: 65100 nM
Compound 4: middle estimate off by 1.3-fold (0.11 log units), on the low side, and the stated range covers the measured number.
By their numbers in this assay, from the lowest: compounds 1, 3, 4 and 2 (each within the scatter of the next).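

In this assay, among these compounds, the change at this aromatic carbon is now read directly for the first time as an exchange of one halogen for another: a 1.1-fold higher number from compound 3 to compound 4 (0.05 log units; within the scatter) shows that chloro and fluoro cannot be told apart here. The second step, a 1.1-fold lower number from compound 2 to compound 4 (0.03 log units; within the scatter), adds that 3-chlorophenyl and 2-methylphenyl also cannot be told apart, so all three benzyl variants on this chain remain within the scatter of one another. The compounds shown offer no measured basis for explaining this flat result.

Still open, on these data alone, is whether any group on this ring can move the number beyond the scatter, for example a carboxylic acid, an amine or a methoxy group. The unsubstituted benzyl group on this same chain would also give the missing reference point for these steps.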